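The source may hold more compounds than are shown below. What is called first, only, known or untested is meant among the compounds shown, and "the series" means these compounds.

In a functional assay on DU-145 cells (Homo sapiens) for inhibition, read by trypan blue exclusion, with a stated time of 96 h (on this read-out higher numbers stand for weaker inhibition of growth and lower numbers for stronger inhibition of growth), compound 3 `Cc1ccc(/C=C(/SCc2ccc(Cl)cc2)C(=O)c2ccc([N+](=O)[O-])cc2)s1` gives 25000 nM. This lies within the usual scatter of compound 1 `Cc1ccsc1/C=C(/SCc1ccc(Cl)cc1)C(=O)c1ccc(Cl)cc1`, which gives 50000 nM, while compound 2 `COc1ccccc1/C=C(/SCc1ccc(Cl)cc1)C(=O)c1ccc([N+](=O)[O-])cc1` gives 10000 nM, a clearly lower number. Among the measured compounds shown here, only one measured step changes a single place in the structure: a 2.5-fold higher number from compound 2 to compound 3 (0.40 log units; beyond the scatter). It is modest, even though 5-methylthiophen-2-yl replaces the quite different 2-methoxyphenyl.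

The next change is more limited, and it falls at that same place, on a double-bonded chain carbon bound to a double-bonded chain carbon: 3-methylthiophen-2-yl in place of 5-methylthiophen-2-yl on a double-bonded chain carbon bound to a double-bonded chain carbon. The result is compound 4 `Cc1ccsc1/C=C(/SCc1ccc(Cl)cc1)C(=O)c1ccc([N+](=O)[O-])cc1`, which has the same atoms as compound 3, joined differently. For the measured compounds named here, compound 1 also carries 3-methylthiophen-2-yl, but it differs elsewhere too, so no measured pair isolates this swap.

Going by the values given here, with only that modest step as a guide, no shift beyond the scatter is expected in this assay. The estimated change is a 1.3-fold lower number from compound 3 to compound 4 (0.10 log units; within the scatter). The expected value for compound 4 is 20000 nM, with an estimated range of 8000 nM to 50000 nM.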

Compound 4, concentration for 50% growth inhibition: > 100000 nM
Compound 4: a limit, no number (the forecaster's own chance of this, stated with the estimate: 10%); middle value at least 5.0-fold (0.69 log units) away from the limit.
By their numbers in this assay, from the lowest: compound 2; then compounds 3 and 1 (each within the scatter of the next). At a limit, above all of these: compound 4.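

In this assay compound 4 gives only a limit, not a number: the limit of > 100000 nM in this assay, at which 1 of the 4 values shown sits. Rearranging the same atoms, with 3-methylthiophen-2-yl in place of 5-methylthiophen-2-yl, gives an at least 4.0-fold higher number from compound 3 to compound 4 (0.60 log units; beyond the scatter), so at this place even moving the methyl group within one ring can matter beyond the scatter. The distance from the 2-methoxyphenyl compound is wider still, an at least 10-fold higher number from compound 2 to compound 4 (1.00 log units; beyond the scatter), whereas an at least 2.0-fold higher number from compound 1 to compound 4 (0.30 log units; that floor lies within the scatter) cannot be read as a real difference, which leaves nitro in place of chloro on an aromatic carbon undecided.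

The compounds shown leave open how a plain phenyl, or a thiophene ring carrying a hydroxymethyl group instead of the methyl, would behave at this place. They also do not explain why moving the methyl group has this effect.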